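Silicon-bearing group to methoxymethoxy: compound 3 to compound 4

A few compounds are considered here, and "the series" means these few. Any claim that something is new, unique, unknown or untested is made for them only; others in the source may bear on it.

Of the compounds shown here, three on the shared core have been measured in a functional assay on SMMC-7721 cells (Homo sapiens) for antiproliferative activity, read by MTT assay, with a stated time of 48 h; a higher number here means a weaker inhibitor, a lower number a stronger inhibitor. Compound 1 `CC(C)=CCC[C@]1(C)/C=C/[C@@H](OC(=O)C=C(C)C)[C@](C)(O)/C=C/C(=O)/C(CCl)=C\C1` gives 840 nM. Compound 2 `CC[Si](CC)(CC)C/C1=C/C[C@](C)(CCC=C(C)C)/C=C/[C@@H](OC(=O)C=C(C)C)[C@](C)(O)/C=C/C1=O` gives 3460 nM. Compound 3 `CC(C)=CCC[C@]1(C)/C=C/[C@@H](OC(=O)C=C(C)C)[C@](C)(O)/C=C/C(=O)/C(C[Si](C)(C)C(C)(C)C)=C\C1` gives 4000 nM, which puts it at the high end of these numbers. Its nearest neighbour is level with it, a 1.2-fold higher number from compound 2 to compound 3 (0.06 log units; within the scatter) being within the scatter, while a 4.8-fold higher number from compound 1 to compound 3 (0.68 log units; beyond the scatter) lies beyond the scatter.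

Compound 4 `COCOC/C1=C/C[C@](C)(CCC=C(C)C)/C=C/[C@@H](OC(=O)C=C(C)C)[C@](C)(O)/C=C/C1=O` differs from compound 3 by one change: a group of 4 heavy atoms (2 carbon, 2 oxygen; no ring) in place of a group of 7 heavy atoms (6 carbon, 1 silicon; no ring), on a saturated chain carbon bound to a double-bonded ring carbon. This is the one place varied so far in the series.

Going by the values given here, three measured steps bear on it. Going from chlorine to a silicon-bearing group gave modest steps, a 4.1-fold higher number from compound 1 to compound 2 (0.61 log units; beyond the scatter) and a 4.8-fold higher number from compound 1 to compound 3 (0.68 log units; beyond the scatter). Exchanging one silicon-bearing group for the other, a 1.2-fold higher number from compound 2 to compound 3 (0.06 log units; within the scatter), changed nothing beyond the scatter. Among the compounds with values here, no group with oxygen has been measured at this place, so the only guide is the span from compound 1 at 840 nM to compound 3 at 4000 nM. A modest move to a lower number in this assay is expected, falling short of that full span. The expected step is a 2.2-fold lower number from compound 3 to compound 4 (0.35 log units; beyond the scatter). For compound 4 the estimate is 1800 nM, with an expected range of 600 nM to 5000 nM.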

Compound 4, half-maximal inhibitory concentration: 3250 nM
Compound 4: the middle estimate sits 1.8-fold (0.26 log units) below what was measured; the measured number falls inside the stated range.
By their numbers in this assay, from the lowest: compound 1; then compounds 4, 2 and 3 (each within the scatter of the next).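

In this assay, methoxymethoxy on a saturated chain carbon bound to a double-bonded ring carbon cannot be told apart from either silicon-bearing group, with a 1.2-fold lower number from compound 3 to compound 4 (0.09 log units; within the scatter) and a 1.1-fold lower number from compound 2 to compound 4 (0.03 log units; within the scatter). The level reading therefore extends beyond silicon-bearing groups: a smaller group with oxygen and hydrogen-bond acceptors lands with them, while chloro remains apart, with a 3.9-fold higher number from compound 1 to compound 4 (0.59 log units; beyond the scatter), leaving compound 1 as the strongest of the four in this assay. No evidence on hand accounts for this grouping of compounds 2, 3 and 4 or for the separation of compound 1.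

Open, from the compounds shown here alone, is whether the lower number of compound 1 is particular to chloro, or whether bromo, fluoro or a free hydroxyl at this place would sit with compound 1 rather than with compounds 2, 3 and 4. Also open, going by these compounds, is whether an amine, a carboxylic acid or a longer chain here would depart from the level reading in this assay, or would fall with the three compounds that cannot be separated.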